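Removing the hydroxy from compound 3: notes toward compound 4

The source may report more compounds than this note shows. Statements on the series, on what has been measured and on what is new or still open speak of the compounds shown alone.

Measured compounds in a functional assay on MCF7 cells (Homo sapiens) for antiproliferative activity, read by MTT assay, with a stated time of 48 h; a lower number here means a stronger inhibitor, a higher number a weaker inhibitor:
compound 1 `COc1ccc(-c2c(Nc3ccc(C)c(O)c3)c3ccc(OC)cc3oc2=O)cc1` gives 34400 nM
compound 2 `COc1ccc(-c2c(Nc3ccc(C)cc3)c3ccc(OC)cc3oc2=O)cc1` gives 66900 nM
compound 3 `COc1ccc(-c2c(Nc3ccc(C)c(O)c3)c3ccc(O)cc3oc2=O)cc1` gives > 100000 nM, which is a limit of the assay and not a number

The change from compound 1 to compound 2 is hydrogen in place of hydroxy on an aromatic carbon. In this assay this gave a 1.9-fold higher number from compound 1 to compound 2 (0.29 log units; within the scatter), so the two values cannot be ordered.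

Compound 1 and compound 3 differ in their cores: hydrogen in place of methyl on an oxygen on an aromatic ring. In this assay this gave an at least 2.9-fold higher number from compound 1 to compound 3 (0.46 log units; beyond the scatter), the value for compound 3 sitting at the limit of > 100000 nM in this assay, at which 1 of the 3 values shown sits.

Compound 4 `COc1ccc(-c2c(Nc3ccc(C)cc3)c3ccc(O)cc3oc2=O)cc1` has not been measured. It differs from compound 3 by hydrogen in place of hydroxy on an aromatic carbon, and the place lines read the same word for word as for the change from compound 1 to compound 2, so this is the same change, now made on the core of compound 3.

For compound 4 the step that the limit leaves unreadable from compound 3 to compound 4 is expected in this assay, resting on the step of a 1.9-fold higher number from compound 1 to compound 2 (0.29 log units; within the scatter), which lay within the scatter. Since compound 3 already sits at the limit of > 100000 nM in this assay, at which 1 of the 3 values shown sits, compound 4 is expected to return a limit as well rather than a number. The estimate for compound 4 in this assay is 190000 nM, with a range from 70000 nM to 500000 nM.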

Compound 4, half-maximal inhibitory concentration: 85500 nM
The estimate for compound 4 lay 2.2-fold (0.35 log units) above the measured number; the measured number falls inside the stated range.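

Hydrogen in place of hydroxy on an aromatic carbon, carried to the core of compound 3, gave in this assay an at least 1.1-fold lower number from compound 3 to compound 4 (0.06 log units; that floor lies within the scatter), and the comparison with the same change on the core of compound 1 stays unresolved: the same change on two cores in this assay, a 1.9-fold higher number (0.29 log units; within the scatter) from compound 1 to compound 2 and an at least 1.1-fold lower number (0.06 log units; that floor lies within the scatter) from compound 3 to compound 4; the limit leaves it open whether they differ

Hydrogen in place of methyl on an oxygen on an aromatic ring, carried to the core without the hydroxy, gave a 1.3-fold higher number from compound 2 to compound 4 (0.11 log units; within the scatter), and the comparison with the same change in the presence of the hydroxy is likewise unresolved: the same change on two cores in this assay, an at least 2.9-fold higher number (0.46 log units; beyond the scatter) from compound 1 to compound 3 and a 1.3-fold higher number (0.11 log units; within the scatter) from compound 2 to compound 4; the limit leaves it open whether they differ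

These pairs show no demonstrated dependence of either change on the core, but they do not show that either change has the same size on both cores, because compound 3 is held at a limit of the assay and not at a number: the limit of > 100000 nM in this assay, at which 1 of the 4 values shown sits.

On these data alone, still open in this assay is what an amine or a carboxylic acid would give in place of the hydroxy on the 3-hydroxy-4-methylphenyl group. Also open, as far as these compounds go, is whether a longer chain in place of the methyl on the core oxygen would give a number that can be read against the values for compound 2 and compound 4.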